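Removing the Bromo Group from Compound 3

The compounds below may be only part of what the source reports. "The series", "measured", "known", "first", "only" and "open" are said of these compounds alone.

Values in a functional assay on MCF7 cells (Homo sapiens) for antiproliferative activity, read by MTT assay, with a stated time of 48 h (a higher number here means a weaker inhibitor, a lower number a stronger inhibitor), so far
- compound 1 `O=C(/C=C/c1ccccc1)Nc1nnc(-c2ccccc2)s1` gives 1.47 ug/mL
- compound 2 `COc1ccc(/C=C/C(=O)Nc2nnc(-c3ccccc3)s2)cc1` gives 0.83 ug/mL
- compound 3 `O=C(/C=C/c1ccc(F)cc1)Nc1nnc(-c2ccc(Br)cc2)s1` gives 1.49 ug/mL

All three values lie within the usual scatter of one another, so compound 3 cannot be separated from the other two. Compound 4 `O=C(/C=C/c1ccc(F)cc1)Nc1nnc(-c2ccccc2)s1` is compound 3 with hydrogen in place of bromo on an aromatic carbon, para to a large group hydrogen in place of bromo on an aromatic carbon and nothing else changed. Within the data shown here, no measured pair tests this change directly. Among the measured compounds shown here, the only measured step is a 1.8-fold lower number from compound 1 to compound 2 (0.25 log units; within the scatter) and it concerns methoxy in place of hydrogen, so it offers only indirect guidance. No step beyond the scatter is therefore expected in this assay for this change. The expected step is a 1.1-fold lower number from compound 3 to compound 4 (0.03 log units; within the scatter) and it remains an estimate. Compound 4 is estimated at 1.4 ug/mL with an expected range from 0.7 ug/mL to 2.8 ug/mL on a later measurement.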

Compound 4, half-maximal inhibitory concentration: 1.45 ug/mL
Compound 4: middle estimate off by 1.0-fold (0.02 log units), on the low side, within the range that was stated.
By their numbers in this assay, from the lowest: compounds 2, 4, 1 and 3 (each within the scatter of the next).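

In this assay, replacing 4-bromophenyl with phenyl gives a 1.0-fold lower number from compound 3 to compound 4 (0.01 log units; within the scatter), the first direct test of this change, and it shows that bromo can be removed from this position without a step beyond the scatter. Fluoro in place of hydrogen on an aromatic carbon gives a 1.0-fold lower number from compound 1 to compound 4 (0.01 log units; within the scatter), and fluoro in place of methoxy gives a 1.7-fold higher number from compound 2 to compound 4 (0.24 log units; within the scatter), so neither swap can be separated from the scatter either. No supporting data are available to explain these results. As far as these compounds go, whether an amine or a carboxylic acid at this position would produce a step beyond the scatter remains open.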